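The compounds below may be only part of what the source reports. "The series", "measured", "known", "first", "only" and "open" are said of these compounds alone.

Measured compounds:
compound 1, `COc1cc(-c2nn(-c3ccc(NC(=O)c4ccc(Cl)c(Cl)c4)cc3)cc2-c2ccncc2)ccc1Cl`, 22400 nM
compound 2, `COc1cc(-c2nn(-c3ccc(NC(=O)c4cc(Cl)cc(Cl)c4)cc3)cc2-c2ccncc2)ccc1Cl`, 7390 nM

Both compounds were tested in a functional assay on M14 cells (Homo sapiens) for antiproliferative activity, read by sulforhodamine B assay, with a stated time of 48 h; on this read-out higher numbers stand for weaker inhibition and lower numbers for stronger inhibition. Of the two numbers, compound 2 has the lower one, and compound 1 sits a clear distance above it: a 3.0-fold lower number from compound 1 to compound 2 (0.48 log units; beyond the scatter). That single step is the whole measured record available here.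

Compound 3, `COc1cc(-c2nn(-c3ccc(NC(=O)c4ccc(Cl)c(C(F)(F)F)c4)cc3)cc2-c2ccncc2)ccc1Cl`, has not yet been measured. It differs from compound 2 in one place: 4-chloro-3-(trifluoromethyl)phenyl in place of 3,5-dichlorophenyl on a carbonyl carbon. Going by the values given here, the only step that touches the same place is the one from compound 1 to compound 2, which swapped the pattern of two chlorine atoms on that ring and gave a modest change. Compound 3 keeps a chlorine where compound 1 had one and adds a trifluoromethyl group, so its ring resembles neither measured pattern exactly. Among the compounds with values here, no measured step shows what a trifluoromethyl group does here, so the direction cannot be read from the data with confidence.

Compound 3 is therefore expected to land close to compound 2, with the step of a 1.2-fold higher number from compound 2 to compound 3 (0.09 log units; within the scatter) possibly within the scatter. The estimate for compound 3 is 9000 nM, with a range from 3000 nM to 30000 nM.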

Compound 3, half-maximal inhibitory concentration: 1920 nM
Beside the measured number, compound 3's estimate is 4.7-fold (0.67 log units) above it, outside the stated range (below it).
By their numbers in this assay, from the lowest: compound 3; then compound 2; then compound 1.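

In this assay, going by these compounds alone, the ring on the carbonyl carbon proves able to give more than a rearrangement of its two chlorines did: 4-chloro-3-(trifluoromethyl)phenyl in place of 3,5-dichlorophenyl brings a 3.8-fold lower number from compound 2 to compound 3 (0.59 log units; beyond the scatter), a modest step that still gives compound 3 the lowest number of the series so far. The sharper comparison is with compound 1. Within the data shown here, only one group changes there: trifluoromethyl in place of chloro on an aromatic carbon gives a 12-fold lower number from compound 1 to compound 3 (1.07 log units; beyond the scatter), a large step that far exceeds a 3.0-fold lower number from compound 1 to compound 2 (0.48 log units; beyond the scatter) seen when only the chlorine pattern changed, so at this place the identity of the group counts for more than the chlorine arrangement did. No supporting measurement is available to explain this gain.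

As far as these compounds go, whether a nitrile, a bromine, an amine or a carboxylic acid in that same place would lower the number further or raise it again remains open. So does whether a ring carrying two trifluoromethyl groups would extend the gain, and whether the same order of compounds would hold in cells other than M14.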